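The source may report more compounds than this note shows. Statements on the series, on what has been measured and on what is new or still open speak of the compounds shown alone.

Compound 1 `COc1ccc(-c2cc(-c3ccc(Cl)cc3)n(C3C(=O)Nc4ccc(Br)cc43)n2)cc1` gives the highest of the two numbers seen so far in a functional assay on cells (Cancer cell lines, Homo sapiens) for cytotoxicity, read by sulforhodamine B assay, with a stated time of 48 h (a lower number here means a stronger inhibitor of growth, a higher number a weaker inhibitor of growth), where compound 1 gives 7650 nM. For the measured compounds named here, its one measured neighbour, compound 2 `COc1ccc(-c2cc(-c3ccc(Cl)cc3)n(C3C(=O)Nc4ccc(Cl)cc43)n2)cc1`, gives 6490 nM in this assay, and the step of a 1.2-fold lower number from compound 1 to compound 2 (0.07 log units; within the scatter) concerns a halogen swap at another site. Compound 3 `O=C1Nc2ccc(Br)cc2C1n1nc(-c2ccc3ccccc3c2)cc1-c1ccc(Cl)cc1` differs from compound 1 by naphthalen-2-yl in place of 4-methoxyphenyl on an aromatic carbon. No measured step touches this aryl group, so nothing shown supports a direction; the only known step lies within the scatter. Compound 3 is therefore expected to give 7000 nM (range 2500 nM to 20000 nM), a step of a 1.1-fold lower number from compound 1 to compound 3 (0.04 log units; within the scatter).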

Compound 3, concentration for 50% growth inhibition: 2570 nM
Estimate against measurement, compound 3: 2.7-fold (0.44 log units) above, within the range that was stated.
By their numbers in this assay, from the lowest: compound 3; then compounds 2 and 1 (each within the scatter of the next).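

Unlike the halogen swap, changing the aryl group on this five-membered aromatic ring with 2 nitrogen gives a step beyond the scatter: in this assay, naphthalen-2-yl in place of 4-methoxyphenyl gives a 3.0-fold lower number from compound 1 to compound 3 (0.47 log units; beyond the scatter), a modest change. This position therefore responds to the group it carries. No evidence is available on the reason for this step.

Compound 3 adds a second aromatic ring and loses the methoxy oxygen in one change, so the compounds shown do not separate these two differences. On these data alone, how a plain phenyl, a pyridyl ring or an amine would read at this position remains open.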